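Moving a Chlorine Around the Phenyl Ring

A few compounds are considered here, and "the series" means these few. Any claim that something is new, unique, unknown or untested is made for them only; others in the source may bear on it.

Compound 1 `CCC(COc1ccccc1Cl)OC(=O)NCc1ccccc1` in an assay for inhibition of zeta-carotene desaturase, chloroplastic/chromoplastic (Capsicum annuum), using a Dixon plot, with a stated time of 8 h (on this read-out lower numbers stand for stronger inhibition and higher numbers for weaker inhibition), gives > 100000 nM, which is a limit of the assay rather than a number.
Compound 2 `CCC(COc1cccc(C)c1)OC(=O)NCc1ccccc1` gives > 100000 nM, also a limit.
Compound 3 `CCC(COc1ccc(Cl)c(Cl)c1)OC(=O)NCc1ccccc1` gives > 100000 nM, again a limit.

Compound 3 therefore stands only at a limit, and so do the two other values shown, since (the limit of > 100000 nM in this assay, at which 3 of the 3 values shown sit). The three steps between the measured compounds, a step that the two limits leave unreadable from compound 1 to compound 2, a step that the two limits leave unreadable from compound 1 to compound 3 and a step that the two limits leave unreadable from compound 2 to compound 3, cannot be read in size or direction, as both ends of each sit at the limit.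

Compound 4 `CCC(COc1cc(Cl)cc(Cl)c1)OC(=O)NCc1ccccc1` is the unmeasured compound. Its difference from compound 3 is 3,5-dichlorophenyl in place of 3,4-dichlorophenyl on an oxygen on a saturated carbon. No measured step bears on this change in a readable way: all three shown steps are unreadable. Nothing in the data points to compound 4 leaving the limit, so the expected outcome is a number no higher from compound 3 to compound 4 (the limit leaves the size open), that is, no readable step. Compound 4 is thus estimated to give 100000 nM, with a range from 30000 nM to 300000 nM, most likely again reported only as a limit.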

Compound 4, half-maximal inhibitory concentration: > 100000 nM
Compound 4: a limit, no number (the forecaster's own chance of this, stated with the estimate: 85%); the middle value lies on the limit itself.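

Compound 4 also gives only a limit in this assay, so its steps from compound 1, compound 2 and compound 3 cannot be read in size or direction: the limit of > 100000 nM in this assay, at which 4 of the 4 values shown sit.

The compounds shown leave open how these four rank against one another, and what change to the shared core would give a readable number.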